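Moving a Nitro Group From Compound 3 to Compound 4

The source may report more compounds than this note shows. Statements on the series, on what has been measured and on what is new or still open speak of the compounds shown alone.

Measured in a functional assay on MDA-MB-231 cells (Homo sapiens) for cytotoxicity, read by MTT assay, with a stated time of 48 h (a higher number here means a weaker inhibitor, a lower number a stronger inhibitor), where each value is a limit of the assay rather than a number:
compound 1 `O=c1ccoc2cc(OCc3cn(Cc4cccc(F)c4)nn3)ccc12` gives > 100000 nM.
compound 2 `O=c1ccoc2cc(OCc3cn(Cc4ccc(F)cc4)nn3)ccc12` gives > 100000 nM.
compound 3 `O=c1ccoc2cc(OCc3cn(Cc4cccc([N+](=O)[O-])c4)nn3)ccc12` gives > 100000 nM.

Compound 3 thus sits at the limit, and so do the other two, as the limit of > 100000 nM in this assay, at which 3 of the 3 values shown sit, records. The steps a step that the two limits leave unreadable from compound 1 to compound 3 and a step that the two limits leave unreadable from compound 2 to compound 3 cannot be sized. Compound 4 `O=c1ccoc2cc(OCc3cn(Cc4ccc([N+](=O)[O-])cc4)nn3)ccc12` differs from compound 3 by 4-nitrophenyl in place of 3-nitrophenyl on a saturated chain carbon bound to an aromatic nitrogen. Among the compounds with values here, the closest measured change, a step that the two limits leave unreadable from compound 1 to compound 2, is also unreadable, so no step here gives a readable size or direction. Compound 4 is therefore expected to behave like compound 3, with an estimated step of a number no higher from compound 3 to compound 4 (the limit leaves the size open). Compound 4 is estimated at 100000 nM, within 50000 nM to 300000 nM.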

Compound 4, half-maximal inhibitory concentration: 71300 nM
Compound 4: middle estimate off by 1.4-fold (0.15 log units), on the high side; the measured number falls inside the stated range.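

Within the data shown here, compound 4, with its 4-nitrophenyl, is the first compound here to give a number rather than a limit at this place, a saturated chain carbon bound to an aromatic nitrogen. This allows three steps to be read: an at least 1.4-fold lower number from compound 3 to compound 4 (0.14 log units; that floor lies within the scatter), an at least 1.4-fold lower number from compound 2 to compound 4 (0.14 log units; that floor lies within the scatter) and an at least 1.4-fold lower number from compound 1 to compound 4 (0.14 log units; that floor lies within the scatter). Each is only a floor, and the other compounds give no number to set against compound 4: the limit of > 100000 nM in this assay, at which 3 of the 4 values shown sit.

Going by these compounds, the true size of these steps remains open. So does whether an amine or a carboxylic acid in place of the nitro group would give a lower number.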